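The compounds below may be only part of what the source reports. "The series", "measured", "known", "first", "only" and "open" are said of these compounds alone.

Of the compounds shown here, three built on a shared core have been measured in an ADME assay on HEK-293T cells (Homo sapiens) for cytotoxicity, read by CCK-8 assay, with a stated time of 48 h; a higher number here means a weaker inhibitor, a lower number a stronger inhibitor. Compound 1 `O=C(Nc1cccc([N+](=O)[O-])c1)N1CCN(S(=O)(=O)c2sccc2-c2ccccc2Oc2ccc(O)c(O)c2)CC1` gives only a limit of the assay, > 20000 nM. Compound 2 `CC(C)c1ccc(Oc2ccc(O)c(O)c2)c(-c2ccsc2S(=O)(=O)NCCNC(=S)Nc2cc(C(F)(F)F)cc(C(F)(F)F)c2)c1` gives 18100 nM, and compound 3 `O=S(=O)(NCCNC(=S)Nc1cc(C(F)(F)F)cc(C(F)(F)F)c1)c1ccc(-c2ccccc2Oc2ccc(O)c(O)c2)s1` gives 12300 nM. Of the two numbers, compound 2 stands highest, but its gap to compound 3 lies within the scatter of repeated measurements, so the two cannot be told apart. the limit of > 20000 nM in this assay, at which 1 of the 3 values shown sits, is where compound 1 sits.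

Compound 4 `O=S(=O)(NCCNC(=S)Nc1cc(C(F)(F)F)cc(C(F)(F)F)c1)c1sccc1-c1ccccc1Oc1ccc(O)c(O)c1` has not yet been measured in this assay. It differs from compound 2 in one place: hydrogen in place of isopropyl on an aromatic carbon. Among the compounds with values here, no measured pair shows what this change does, and the values at hand are all large or at the limit. For compound 4 the expected step is a 1.1-fold lower number from compound 2 to compound 4 (0.05 log units; within the scatter), which stays within the scatter. Compound 4 is therefore estimated at 16000 nM in this assay, with a range from 7000 nM to 35000 nM.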

Compound 4, half-maximal inhibitory concentration: 7500 nM
For compound 4 the middle estimate is 2.1-fold (0.33 log units) above the measured one; measured number inside the range.
By their numbers in this assay, from the lowest: compounds 4, 3 and 2 (each within the scatter of the next, the first and the last beyond it). At a limit, above all of these: compound 1.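

In this assay, replacing isopropyl with hydrogen on the aromatic carbon para to the 3,4-dihydroxyphenoxy group gives a 2.4-fold lower number from compound 2 to compound 4 (0.38 log units; beyond the scatter). Within the data shown here, this is the first comparison here between compounds that differ in one place, and it shows that this position can shift the reading by a modest but real amount, with the hydrogen compound giving the lower number. Nothing measured here explains why the number moves with this change.

A single pair cannot show whether any group at this carbon would raise the number or whether the rise is particular to isopropyl; a methyl group, a methoxy group or an amine in the same place would help to separate those cases. It also leaves open whether the same swap would have a similar effect on the core of compound 1.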